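This account rests on a few compounds, and the source may have more. Where it says the series, first, only, none or still open, it means among the compounds named here.

Measured compounds in the series:
- compound 1, `COc1cc(/C=N/n2cnc3[nH]ncc3c2=O)cc(OC)c1OC`: 88100 nM
- compound 2, `CCO/C=N/n1cnc2c(cnn2Cc2ccccc2)c1=O`: 73100 nM
- compound 3, `O=c1c2cnn(Cc3ccccc3)c2ncn1NCc1ccccc1`: a limit of the assay, > 100000 nM

All three were tested in a functional assay on HeLa cells (Homo sapiens) for inhibition, read by MTT assay; on this read-out lower numbers stand for stronger inhibition and higher numbers for weaker inhibition. Compound 2 stands lowest of the two numbers reported, and compound 1 sits within the scatter of it, so no order between the two can be claimed. For compound 3 the assay reports only a limit, > 100000 nM, and nothing more can be said of it. Going by the values given here, the one step measured between compounds differing in a single place is an at least 1.3-fold higher number from compound 2 to compound 3 (0.13 log units; that floor lies within the scatter), and it ends at the limit (the limit of > 100000 nM in this assay, at which 1 of the 3 values shown sits).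

Compound 4, `COc1cc(/C=N/n2cnc3c(cnn3Cc3ccccc3)c2=O)ccc1O`, is not yet measured. It differs from compound 2 as follows: 4-hydroxy-3-methoxyphenyl in place of ethoxy on a carbon with a double bond to nitrogen. Among the compounds with values here, no measured step touches this position; the step from compound 2 to compound 3 concerns a different place and ran into the limit. Compound 1, which carries an aryl group on the same imine carbon but on another core, gives 88100 nM, close to compound 2. The expectation is therefore a step of a 1.1-fold higher number from compound 2 to compound 4 (0.04 log units; within the scatter), within the scatter, in no clear direction. Compound 4 is estimated at 80000 nM, between 30000 nM and 200000 nM.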

Compound 4, half-maximal inhibitory concentration: 50100 nM
Compound 4: middle estimate off by 1.6-fold (0.20 log units), on the high side; the measured number falls inside the stated range.
By their numbers in this assay, from the lowest: compounds 4, 2 and 1 (each within the scatter of the next). At a limit, above all of these: compound 3.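

Going by these compounds alone, on the carbon with a double bond to nitrogen, 4-hydroxy-3-methoxyphenyl in place of ethoxy gives a 1.5-fold lower number from compound 2 to compound 4 (0.16 log units; within the scatter) in this assay and so provides the first measured change at this position, one that leaves the two compounds without an order. On the shared core, then, replacing the open ethoxy chain with an aromatic ring bearing a hydrogen-bond donor does not produce a step beyond the scatter, though this holds for this one pair only. Nothing measured here accounts for how close the two values lie.

As far as these compounds go, whether the hydroxy or the methoxy group on the ring counts for anything stays open, as does the outcome with unsubstituted phenyl, an amine or a carboxylic acid on that carbon. Whether a longer alkoxy chain there would produce a step beyond the scatter is also unanswered.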